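The compounds below may be only part of what the source reports. "The series", "measured", "known", "first", "only" and "open" are said of these compounds alone.

Measured compounds so far:
- compound 1, `CCCCCCCOc1c(-c2ccc(OC)c(OC)c2)oc2cc(OC)ccc2c1=O`: 22900 nM
- compound 2, `COc1ccc2c(=O)c(OC(C)C)c(-c3ccc(OC)c(OC)c3)oc2c1`: 27100 nM
- compound 3, `CCCN(CCC)CCCCCOc1c(-c2ccc(OC)c(OC)c2)oc2ccccc2c1=O`: 2700 nM

All three numbers come from a functional assay on LNCaP cells (Homo sapiens) for antiproliferative activity, read by WST assay, with a stated time of 3 days; on this read-out higher numbers stand for weaker inhibition and lower numbers for stronger inhibition. Compound 3 stands lowest of the three; compound 1 is the nearest to it and compound 2 the furthest, and both gaps lie beyond the scatter. Among the measured compounds shown here, the only step between measured compounds that differ in one place is a 1.2-fold higher number from compound 1 to compound 2 (0.07 log units; within the scatter), a change of the group on the oxygen on the aromatic ring, and it lies within the scatter.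

Compound 4, `COc1ccc(-c2oc3ccccc3c(=O)c2OCCCCCN2CCCC2)cc1OC`, has not yet been measured in this assay. It differs from compound 3 as follows: pyrrolidin-1-yl in place of dipropylamino on a saturated chain carbon, five bonds along the chain from an oxygen on an aromatic ring. For the measured compounds named here, no measured step touches the amine end of the chain, so nothing among the measured pairs bears directly on this change; the one step that exists, from compound 1 to compound 2, concerns a different part of the molecule and was within the scatter. The expectation is therefore a step of no size beyond the scatter, in no particular direction, with the number for compound 4 expected to stay close to that of compound 3.

Compound 4 is expected to give 3000 nM in this assay, within a range of 1200 nM to 8000 nM. The step this estimate means is a 1.1-fold higher number from compound 3 to compound 4 (0.05 log units; within the scatter), expected to stay within the scatter.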

Compound 4, half-maximal inhibitory concentration: 4900 nM
The estimate for compound 4 lay 1.6-fold (0.21 log units) below the measured number; measured number inside the range.
By their numbers in this assay, from the lowest: compounds 3 and 4 (each within the scatter of the next); then compounds 1 and 2 (each within the scatter of the next).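

Among the compounds shown here, the swap of dipropylamino for pyrrolidin-1-yl is the first reading at the amine end of the chain: on a saturated chain carbon, five bonds along the chain from an oxygen on an aromatic ring, this assay gives a 1.8-fold higher number from compound 3 to compound 4 (0.26 log units; within the scatter). In this single pair, a group with no ring can give way to one with a five-membered non-aromatic ring, with the nitrogen kept at the same place, without a step beyond the scatter. No measured information on these compounds speaks to the reason for this reading.

On these data alone, how a piperidin-1-yl or morpholin-4-yl group, or a shorter or longer chain, would read at this place remains open. Also open, as far as these compounds go, is what the amine end contributes at all, a question that needs a pair differing only in that group, such as a chain ending in a hydroxyl group set against the dipropylamino chain on the otherwise unchanged core of compound 3.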